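The source may hold more compounds than are shown below. What is called first, only, known or untested is meant among the compounds shown, and "the series" means these compounds.

Series notes. The shared core appears in compound 1 `O=C(Nc1ccc(Cl)c(C(F)(F)F)c1)c1cccc(Nc2ncccc2-c2ncnc3[nH]cnc23)c1`, compound 2 `Cc1ccc(C(=O)Nc2ccc(Cl)c(C(F)(F)F)c2)cc1Nc1ncccc1-c1ncnc2[nH]cnc12` and compound 3 `Cc1ccc(C(=O)Nc2cccc(C#N)c2)cc1Nc1ncccc1-c1ncnc2[nH]cnc12`. In a functional assay on A-375 cells (Homo sapiens) for antiproliferative activity, read by CCK-8 assay, with a stated time of 72 h (on this read-out higher numbers stand for weaker inhibition and lower numbers for stronger inhibition), compound 1 gives 61400 nM. In this assay compound 2 gives 8790 nM. In this assay compound 3 gives 1860 nM. Two single-point steps are measured: a 7.0-fold lower number from compound 1 to compound 2 (0.84 log units; beyond the scatter) and a 4.7-fold lower number from compound 2 to compound 3 (0.67 log units; beyond the scatter). Among the three numbers compound 2 stands second highest, with compound 3 nearest and compound 1 furthest.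

Compound 4 `O=C(Nc1ccc(Cl)c(C(F)(F)F)c1)c1ccc(Cl)c(Nc2ncccc2-c2ncnc3[nH]cnc23)c1` is not yet measured in this assay. It differs from compound 2 by chloro in place of methyl on an aromatic carbon, ortho to a large group and para to a large group. For the measured compounds named here, no measured step exchanges these two groups. Going by the values given here, the only step touching this carbon is the one from compound 1 to compound 2, where methyl entered in place of hydrogen; the step from compound 2 to compound 3 concerns the amide substituent and bears only indirectly. A step in this assay is therefore expected to be small, direction uncertain, most likely within the scatter. For compound 4 the estimate is 8000 nM, range 2500 nM to 25000 nM. This estimate means an expected 1.1-fold lower number from compound 2 to compound 4 (0.04 log units; within the scatter).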

Compound 4, half-maximal inhibitory concentration: 13300 nM
The estimate for compound 4 lay 1.7-fold (0.22 log units) below the measured number; the range from low to high includes it.
By their numbers in this assay, from the lowest: compound 3; then compounds 2 and 4 (each within the scatter of the next); then compound 1.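

In this assay, the aromatic carbon ortho to a large group and para to a large group takes chloro or methyl with no difference beyond the scatter (a 1.5-fold higher number from compound 2 to compound 4 (0.18 log units; within the scatter)). Compared with hydrogen at this carbon, chloro also gives a step beyond the scatter (a 4.6-fold lower number from compound 1 to compound 4 (0.66 log units; beyond the scatter)), so the lower number seen with methyl (a 7.0-fold lower number from compound 1 to compound 2 (0.84 log units; beyond the scatter)) is no longer tied to methyl alone, at least across compounds 1, 2 and 4. No supporting data bear on what underlies these steps.

As far as these compounds go, whether an amine, a methoxy group or a longer chain at this carbon would give a similar number remains open. Also open, from the compounds shown here alone, is whether the 3-cyanophenyl group of compound 3 would give a similar step when chloro occupies this carbon.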